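The compounds below may be only part of what the source reports. "The series", "measured", "known", "first", "only" and "open" are said of these compounds alone.

In a functional assay on MCF7 cells (Homo sapiens) for cytotoxicity, read by MTT assay, with a stated time of 72 h (a lower number here means a stronger inhibitor of growth, a higher number a weaker inhibitor of growth), three related compounds have been measured. Compound 1, with the structure `C[Se]/C(=N\C(=O)c1cc2ccccc2s1)NC(=O)c1cc2ccccc2s1`, gives 5070 nM in this assay. Compound 2, with the structure `CS/C(=N\C(=O)c1sccc1Cl)NC(=O)c1sccc1Cl`, gives 10300 nM in this assay, and compound 3, with the structure `CS/C(=N\C(=O)c1cnc2ccccc2c1)NC(=O)c1cnc2ccccc2c1`, gives 23900 nM in this assay. Compound 1 stands at the lowest number of the three: its gap to compound 2 and its larger gap to compound 3 both lie beyond the usual scatter of repeated measurements, so compound 1 is the strongest inhibitor of growth among them.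

Compound 4, with the structure `O=C(/N=C(/NC(=O)c1cc2ccccc2s1)[Se]Cc1ccccc1)c1cc2ccccc2s1`, has not yet been measured in this assay. It differs from compound 1 in one place:

phenyl in place of hydrogen on a saturated chain carbon bound to a selenium atom

Cut one bond further out, the same difference reads methyl to benzyl. Among the compounds with values here, no measured pair in this set shows what such a change does, so the expectation rests on compound 1 alone. The step is expected to be small, and no direction beyond the scatter is expected, with the estimated change reading a 1.3-fold lower number from compound 1 to compound 4 (0.10 log units; within the scatter). Compound 4 is therefore expected to give about 4000 nM in this assay, within a range from 1500 nM to 12000 nM.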

Compound 4, concentration for 50% growth inhibition: 37900 nM
For compound 4 the middle estimate is 9.5-fold (0.98 log units) below the measured one; the measured number lies above the stated range.
By their numbers in this assay, from the lowest: compound 1; then compound 2; then compounds 3 and 4 (each within the scatter of the next).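

In this assay, phenyl in place of hydrogen on a saturated chain carbon bound to a selenium atom gives a 7.5-fold higher number from compound 1 to compound 4 (0.87 log units; beyond the scatter) and so weakens growth inhibition by more than the scatter. Within the data shown here, this is the first reading of any change at this position, and it shows that the activity of compound 1 is not indifferent to what is placed there: the methyl to benzyl change is a clear loss rather than a neutral step. No measurement available here explains this loss.

The compounds shown leave open whether an ethyl group or a longer chain in that place would bring a loss of similar size, or whether a benzyl group with an amine on its phenyl ring would behave like compound 4. They also leave open whether the same change would give a similar step with sulfur in place of selenium.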